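The source may hold more compounds than are shown below. What is called first, only, known or untested is meant among the compounds shown, and "the series" means these compounds.

Measured in a functional assay on MCF7 cells (Homo sapiens) for cytotoxicity, read by sulforhodamine B assay, with a stated time of 72 h; on this read-out lower numbers stand for stronger inhibition and higher numbers for weaker inhibition:
- compound 1 `O=c1c(CNc2ccc(S(=O)(=O)Nc3ccccn3)cc2)coc2ccccc12`: > 100000 nM
- compound 2 `Cc1cc(C)nc(NS(=O)(=O)c2ccc(N3C(=O)/C(=C/c4coc5ccccc5c4=O)N=C3c3ccccc3)cc2)n1`: 99700 nM

In this assay compound 1 gives > 100000 nM, which is a limit and not a number. Compound 1 therefore has no exact position on this scale, and the comparison that follows starts from that limit.

The next compound to be tested is compound 3 `O=c1c(CNc2ccc(S(=O)(=O)Nc3nccs3)cc2)coc2ccccc12`. It keeps the rest of compound 1 and carries 1,3-thiazol-2-yl in place of pyridin-2-yl on a sulfonamide nitrogen.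

Among the compounds with values here, no measured pair of compounds shows what this exchange does, so the expectation rests on the small size of the structural change alone. The expected step is a number no higher from compound 1 to compound 3 (the limit leaves the size open), which means no change beyond the scatter in either direction.

For compound 3 the estimated value is 100000 nM, with an expected range from 30000 nM to 200000 nM.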

Compound 3, half-maximal inhibitory concentration: 58600 nM
Estimate against measurement, compound 3: 1.7-fold (0.23 log units) above; low and high end bracket the measured number.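

In this assay, exchanging the aromatic ring on the sulfonamide nitrogen gives an at least 1.7-fold lower number from compound 1 to compound 3 (0.23 log units; that floor lies within the scatter). With this exchange, compound 3 puts an exact number on this series at 58600 nM, so a five-membered aromatic ring with 2 hetero atoms is tolerated here without the value leaving the measurable range. Compound 1 has only a limit, > 100000 nM, and the true size of the step remains unknown because of that limit: the limit of > 100000 nM in this assay, at which 1 of the 3 values shown sits.

From the compounds shown here alone, it remains open how far the number would move with a non-aromatic group on this nitrogen, such as a methyl group or a morpholine ring. Going by these compounds, it is equally open whether a carboxylic acid on the thiazole ring of compound 3 would bring the value clearly beyond the scatter.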